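From Propyl to Ethyl: A Step Expected to Stay Flat

The source may hold more compounds than are shown below. What is called first, only, known or untested is meant among the compounds shown, and "the series" means these compounds.

In a functional assay on the whole organism (blood, strain albino) with Mus musculus as the target, with stated times of 6 days and 4 h, at a dose of 0.4 mmol/kg by the oral route (a higher number here means more inhibition at the dose given (going by the name of the read-out), a lower number less inhibition), compound 1 `CCNC(=S)NS(=O)(=O)c1ccc(-n2nc(C(=O)O)cc2C)cc1` gives -2%. Compound 2 `CCCNC(=S)NS(=O)(=O)c1ccc(-n2nc(C)cc2C)cc1` reaches only a limit in this assay, < 1%, so its standing is a boundary rather than a number (the limit of < 1% in this assay, at which 1 of the 2 values shown sits). Compound 3 `CCNC(=S)NS(=O)(=O)c1ccc(-n2nc(C)cc2C)cc1` differs from compound 2 by hydrogen in place of methyl on a saturated chain carbon, two bonds along the chain from an amide-type nitrogen. Within the data shown here, no measured pair is separated by one such change, and both values shown sit at the floor of the read-out, so the step that the limit leaves unreadable from compound 2 to compound 3 is expected to be none beyond the scatter. Compound 3 is therefore estimated at 0%, within -10% to 10%.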

Compound 3, a percentage reported as inhibition, in the whole organism at one dose (the size of the read-out at that dose, not a potency): 0%
The estimate for compound 3 equals the measured number at the digits printed, and the stated range covers the measured number.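

In this assay, among these compounds, methyl in place of carboxy on an aromatic carbon gives a number 2 percentage points higher from compound 1 to compound 3 (within the scatter) and so offers the first readable step. At this position, the assay does not tell carboxy and methyl apart at the dose given. The step from propyl to ethyl cannot be read, because compound 2 holds only a limit: the limit of < 1% in this assay, at which 1 of the 3 values shown sits. As far as these compounds go, what remains open is whether an amine in place of carboxy, or butyl in place of propyl, would carry inhibition beyond the scatter.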